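Bromo for acetyl on the pendant phenyl of compound 3

A few compounds are considered here, and "the series" means these few. Any claim that something is new, unique, unknown or untested is made for them only; others in the source may bear on it.

Compound 3 `CC(=O)c1ccc(-c2cn3ccnc3c(-c3ccc4ncn(C5CCCCC5)c4c3)n2)cc1` stands second highest of the three numbers measured in a functional assay on NCI/ADR-RES cells (Homo sapiens) for inhibition, read by sulforhodamine B assay, with a stated time of 48 h, tested at 10 uM (on this read-out lower numbers stand for less inhibition and higher numbers for more inhibition at the one concentration tested (going by the name of the read-out)), with 4.17%. Its nearest neighbour is compound 2 `Fc1ccc(-c2cn3ccnc3c(-c3ccc4ncn(C5CCCCC5)c4c3)n2)cc1`, which gives 0.69%; the step of a number 3.5 percentage points higher from compound 2 to compound 3 (within the scatter) lies within the scatter. Furthest away is compound 1 `O=Cc1ccc(-c2cn3ccnc3c(-c3ccc4ncn(C5CCCCC5)c4c3)n2)cc1`, which gives 37.4%; the step of a number 33.2 percentage points lower from compound 1 to compound 3 (beyond the scatter) is beyond the scatter, as is a number 36.7 percentage points lower from compound 1 to compound 2 (beyond the scatter).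

Compound 4 `Brc1ccc(-c2cn3ccnc3c(-c3ccc4ncn(C5CCCCC5)c4c3)n2)cc1` differs from compound 3 by bromo in place of acetyl on an aromatic carbon. For the measured compounds named here, two measured steps bear on it. The acetyl of compound 3 and the fluoro of compound 2 give numbers within the scatter of each other, so exchanging one small para group for another has so far not moved the read-out. Going by the values given here, the only large step, a number 36.7 percentage points lower from compound 1 to compound 2 (beyond the scatter), involves the formyl of compound 1 and does not concern compound 4. No step beyond the scatter is therefore expected in this assay: the estimated step is a number 1.2 percentage points lower from compound 3 to compound 4 (within the scatter). Compound 4 is expected to give 3%, between -8% and 15%.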

Compound 4, a percentage reported as inhibition, at one concentration (the size of the read-out at that concentration, not a potency): 30.5%
Compound 4: the middle estimate sits 27.5 percentage points below what was measured, and the stated range ends below it.
By their numbers in this assay, from the lowest: compounds 2 and 3 (each within the scatter of the next); then compounds 4 and 1 (each within the scatter of the next).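

In this assay the formyl of compound 1 no longer stands alone: a number 26.3 percentage points higher from compound 3 to compound 4 (beyond the scatter) and a number 29.8 percentage points higher from compound 2 to compound 4 (beyond the scatter) show that another exchange on this aromatic carbon, para to a large group, can also move the read-out, while a number 6.9 percentage points lower from compound 1 to compound 4 (within the scatter) leaves bromo and formyl within the scatter of each other. The four compounds therefore fall into two sets, compounds 2 and 3 and compounds 1 and 4, and a carbonyl does not sort them, since the acetyl of compound 3 and the formyl of compound 1 fall in different sets. Nothing at hand explains this split.

Going by these compounds, whether chloro, an amine or a carboxylic acid at this place would join compounds 1 and 4 or compounds 2 and 3 remains open. On these data alone, how these single-concentration numbers relate to potency also remains open.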